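Expecting Compound 3 from Two Measured Compounds

The source may report more compounds than this note shows. Statements on the series, on what has been measured and on what is new or still open speak of the compounds shown alone.

Compound 1 `C=C1OC(=O)C=C1Cc1ccc(NC(=O)/C=C/c2ccccc2)cc1` gives 9490 nM
Compound 2 `C=C1OC(=O)C=C1Cc1ccc(NC(=O)c2ccccc2)cc1` gives > 50000 nM (a limit of the assay)

Both readings come from a functional assay on MCF7 cells (Homo sapiens) for cytotoxicity, read by MTT assay, with a stated time of 48 h; a higher number here means a weaker inhibitor, a lower number a stronger inhibitor. Among the measured compounds shown here, compound 1 gives 9490 nM and holds the only exact number so far. The reading for compound 2 is > 50000 nM and is a limit, not a number.

One measured step is available. With phenyl in place of 2-phenylethenyl on a carbonyl carbon, the change is an at least 5.2-fold higher number from compound 1 to compound 2 (0.72 log units; beyond the scatter) and lies beyond the scatter. That step alters the same side of the molecule as the new change but removes the ethenyl link, which compound 3 keeps.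

Compound 3 `C=C1OC(=O)C=C1Cc1ccc(NC(=O)/C=C/c2ccccc2F)cc1` keeps the core of compound 1 and differs by fluoro in place of hydrogen on an aromatic carbon with fluoro in place of hydrogen on an aromatic carbon, ortho to a large group. For the measured compounds named here, no measured pair tests a substituent on this ring, so no step beyond the scatter is expected in this assay and no direction is favoured. The expected change is a 1.2-fold lower number from compound 1 to compound 3 (0.07 log units; within the scatter) in this estimate. For compound 3 the estimated value is 8000 nM with an expected range from 3000 nM to 21000 nM in this assay.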

Compound 3, half-maximal inhibitory concentration: 13800 nM
Beside the measured number, compound 3's estimate is 1.7-fold (0.24 log units) below it; the measured number falls inside the stated range.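

In this assay, the step for fluoro in place of hydrogen on an aromatic carbon, ortho to a large group, reads a 1.5-fold higher number from compound 1 to compound 3 (0.16 log units; within the scatter), so the two readings cannot be told apart. Among the compounds shown here, the earlier pair spoke only to the ethenyl link, whereas phenyl to 2-fluorophenyl is the first measured change on the ring itself, and this single fluorine gives no step beyond the scatter at this position. Compound 2 remains the only reading that is a limit and not a number, so it offers no exact value to set against the new one: the limit of > 50000 nM in this assay, at which 1 of the 3 values shown sits.

The compounds shown test a single small substituent at a single place, so it remains open whether a chlorine atom, a methoxy group, a trifluoromethyl group or an amine at this position would give a step beyond the scatter. Also open is whether fluoro elsewhere on the same ring, or a carboxylic acid there, would read as compound 3 does, since no pair shown tests a second position or a second substituent on this ring.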